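The source may report more compounds than this note shows. Statements on the series, on what has been measured and on what is new or still open speak of the compounds shown alone.

Of the compounds shown here, two of a shared core have been measured in an assay on isolated protein for inhibition of aldehyde dehydrogenase 1A1 (Homo sapiens), read by spectrophotometry, tested at 10 uM; a higher number here means more inhibition at the concentration tested (going by the name of the read-out), a lower number less inhibition. Compound 1, `Cc1cccc(Cn2c(CN3CCN(C(=O)c4ccc([N+](=O)[O-])cc4)CC3)nc3ccccc32)c1`, gives 24.3% in this assay. Compound 2, `Cc1ccc(Cn2c(CN3CCN(C(=O)C4CC4)CC3)nc3ccccc32)cc1`, gives 51.5% in this assay, the higher of the two numbers, and its gap to compound 1 lies beyond the scatter. The two compounds differ in more than one place, so nothing can be drawn from them about any single change.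

The step under consideration leads from compound 2 to compound 3, `O=C(C1CC1)N1CCN(Cc2nc3ccccc3n2Cc2cccc(Cl)c2)CC1`, which has not yet been measured in this assay. The change is 3-chlorophenyl in place of 4-methylphenyl on a saturated chain carbon bound to an aromatic nitrogen. Within the data shown here, no measured pair in this set shows this change, so there is no basis for expecting a step of any particular direction; the step is expected to stay within the scatter of this assay, with the number for compound 3 close to that of compound 2.

On that basis, the step from compound 2 to compound 3 is estimated as a number 3.5 percentage points lower from compound 2 to compound 3 (within the scatter). Compound 3 is therefore estimated to give 48% in this assay, with a range from 25% to 70%.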

Compound 3, a percentage reported as inhibition, at one concentration (the size of the read-out at that concentration, not a potency): 71.6%
Beside the measured number, compound 3's estimate is 23.6 percentage points below it; the measured number lies above the stated range.
By their numbers in this assay, from the lowest: compound 1; then compound 2; then compound 3.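

In this assay, putting 3-chlorophenyl in place of 4-methylphenyl on a saturated chain carbon bound to an aromatic nitrogen gives a number 20.1 percentage points higher from compound 2 to compound 3 (beyond the scatter). Among these compounds, this is the first single change in the set, so it shows that the number responds to the aryl group at this position, which compound 1 and compound 2 could not show because they differ in more than one place. The two groups match in heavy atoms, hydrogen-bond donors and hydrogen-bond acceptors, so those counts do not separate them, and nothing measured here bears on why the number rises.

The step swaps the substituent and its ring position together, so the compounds shown cannot say whether the chlorine, its place on the ring or the pair accounts for the rise. With the rest of compound 3 unchanged, 4-chlorophenyl and 3-methylphenyl would separate these two parts of the change, while 3-methoxyphenyl or 3-aminophenyl would test how far the position accepts groups other than chlorine.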